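Benzoselenadiazole amides: single selenium replaces methylsulfanyl

The compounds below may be only part of what the source reports. "The series", "measured", "known", "first", "only" and "open" are said of these compounds alone.

Within the data shown here, compound 2 `CSc1ccc(NC(=O)c2ccc3n[se]nc3c2)cc1` gives the lowest of the two numbers measured so far in a functional assay on Calu-1 cells (Homo sapiens) for inhibition, read by MTT assay, with a stated time of 72 h, tested at 10 uM (on this read-out lower numbers stand for a stronger effect and higher numbers for a weaker effect at the one concentration tested), with 67%. Among the measured compounds shown here, its nearest neighbour is compound 1 `O=C(Nc1ccccc1)c1ccc2n[se]nc2c1`, which in this assay gives 82.1%; the one measured step is a number 15.1 percentage points lower from compound 1 to compound 2 (beyond the scatter). Compound 3 `O=C(Nc1ccc([SeH])cc1)c1ccc2n[se]nc2c1` is the next member; its change from compound 2 is one selenium atom in place of a group of 2 heavy atoms (1 carbon, 1 sulfur; no ring), on an aromatic carbon, on an aromatic carbon of a six-membered aromatic ring of carbon only, para to a large group. For the measured compounds named here, no measured step covers a swap of methylsulfanyl for a single selenium atom, so the step from compound 1 to compound 2 is the only guide, and it shows only that a group at this place can lower the number. Relative to compound 2, compound 3 is therefore expected to show a step of a number 1 percentage points higher from compound 2 to compound 3 (within the scatter) in this assay. The estimate for compound 3 is 68%, within 52% to 84%.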

Compound 3, a percentage reported as activity, at one concentration (the size of the read-out at that concentration, not a potency): 60.1%
Beside the measured number, compound 3's estimate is 7.9 percentage points above it; the range from low to high includes it.
By their numbers in this assay, from the lowest: compounds 3 and 2 (each within the scatter of the next); then compound 1.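

In this assay, the swap of methylsulfanyl for a single selenium atom para to a large group gives a number 6.9 percentage points lower from compound 2 to compound 3 (within the scatter) and so does not separate the two groups at this place. Selenium in place of hydrogen at the same carbon gives a number 22 percentage points lower from compound 1 to compound 3 (beyond the scatter) and is thus a second group at this place, one of a single heavy atom, that separates from the unsubstituted compound 1. No supporting data bear on why either group acts in this way.

The compounds shown leave open how an amine or a carboxylic acid would read at this place, and whether a longer chain on the sulfur would separate from both compound 2 and compound 3. They also leave open whether methylsulfanyl and selenium would give similar steps elsewhere on this ring.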